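Compound 4: amino for methoxy under a cytotoxicity limit

The source may hold more compounds than are shown below. What is called first, only, known or untested is meant among the compounds shown, and "the series" means these compounds.

Compound 1 (`O=C(/C=C/c1ccc2c(c1)B(O)OC2)c1ccccc1O`), compound 2 (`Nc1ccc(C(=O)/C=C/c2ccc3c(c2)B(O)OC3)cc1`) and compound 3 (`COc1cccc(C(=O)/C=C/c2ccc3c(c2)B(O)OC3)c1`) share one core and were all tested in an ADME assay on L929 cells (Mus musculus) for cytotoxicity, read by resazurin assay, with a stated time of 72 h; on this read-out higher numbers stand for weaker inhibition and lower numbers for stronger inhibition. Compound 1 gives > 10 ug/mL, which is a limit. Compound 2 gives > 10 ug/mL, also a limit. Compound 3 gives > 10 ug/mL, again a limit and not a number. The series therefore stands at the limit of > 10 ug/mL in this assay, at which 3 of the 3 values shown sit, and compound 3 has no exact place in it.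

Compound 4 (`Nc1cccc(C(=O)/C=C/c2ccc3c(c2)B(O)OC3)c1`) differs from compound 3 by amino in place of methoxy on an aromatic carbon, meta to a large group (amino in place of methoxy on an aromatic carbon). Among the measured compounds shown here, the only measured step is a step that the two limits leave unreadable from compound 1 to compound 2, and it also brings in an amino group, so it shows that compound 2 stays at the limit but gives no size to carry over. No shift beyond the scatter is expected in this assay, in either direction. The expected step is a step that the limit leaves unreadable from compound 3 to compound 4. Compound 4 is estimated at 15 ug/mL, with an expected range from 6 ug/mL to 40 ug/mL, and most likely reported as a limit again.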

Compound 4, half-maximal inhibitory concentration: 10 ug/mL
Compound 4: middle estimate off by 1.5-fold (0.18 log units), on the high side; the measured number falls inside the stated range.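

Notes on this position: with amino on the aromatic carbon meta to a large group, compound 4 gives 10 ug/mL in this assay, the first exact number in the series, and amino in place of methoxy on that carbon is a number no higher from compound 3 to compound 4 (the limit leaves the size open). Compound 3, with methoxy at that place, remains a limit at > 10 ug/mL, and so does each of the other two compounds. The other two new steps are a number no higher from compound 2 to compound 4 (the limit leaves the size open) and a number no higher from compound 1 to compound 4 (the limit leaves the size open), so the sizes of all three new steps cannot be read. The exact number therefore sets one anchor for the shared core, while the rest of the series stays where it was: the limit of > 10 ug/mL in this assay, at which 3 of the 4 values shown sit.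

Still open, from the compounds shown here alone, is how far compound 1, compound 2 and compound 3 actually lie from compound 4 in this assay. Also open, going by these compounds, is whether a carboxylic acid or an acetamide on the same aromatic carbon would give an exact number or another limit.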